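The source may report more compounds than this note shows. Statements on the series, on what has been measured and on what is new or still open speak of the compounds shown alone.

Compound 3 `Cc1nc(C(NC(=O)C(=O)Nc2ccc(F)cc2F)C2CCCCN2)sc1CCO` carries the shared core of the series. In an ADME assay on TZM-b1 cells (Homo sapiens) for cytotoxicity, read by XTT assay, with a stated time of 3 days (a lower number here means that less compound is tolerated, a higher number that more compound is tolerated), compound 3 gives > 84000 nM, a limit of the assay rather than a number. Compound 1 `Cc1ccc(NC(=O)C(=O)NC(c2nc(C)c(CCO)s2)C2CCCCN2)cc1F` likewise gives only a limit, > 85000 nM, in this assay. Compound 2 `Cc1nc(C(NC(=O)C(=O)Nc2ccc(Cl)c(F)c2)C2CCCCN2)sc1CCO` gives 61000 nM in this assay. The steps of an at least 1.3-fold lower number from compound 1 to compound 2 (0.14 log units; that floor lies within the scatter) and an at least 1.3-fold higher number from compound 2 to compound 3 (0.13 log units; that floor lies within the scatter) sit at floors within the scatter, and the step that the two limits leave unreadable from compound 1 to compound 3 cannot be read. Compound 4 `Cc1nc(C(NC(=O)C(=O)NC2CCCCCC2)C2CCCCN2)sc1CCO` differs from compound 3 by cycloheptyl in place of 2,4-difluorophenyl on an amide-type nitrogen. Going by the values given here, no measured step exchanges an aromatic group for a non-aromatic ring, so none bears directly on this change; the values shown sit at or near the limit of > 84000 nM in this assay, at which 1 of the 3 values shown sits, and (the limit of > 85000 nM in this assay, at which 1 of the 3 values shown sits). The step expected for compound 4 is an at least 1.0-fold lower number from compound 3 to compound 4 (0.02 log units; that floor lies within the scatter), not beyond the scatter. The estimate for compound 4 is 80000 nM, within 40000 nM to 130000 nM.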

Compound 4, half-maximal cytotoxic concentration: > 88000 nM
Compound 4: only a limit was reported; the forecaster's own chance of this, stated with the estimate: 60%; at least 1.1-fold (0.04 log units) between middle value and limit.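

In this assay compound 4, with cycloheptyl on the amide-type nitrogen, gives only a limit of the assay, so a non-aromatic ring at this place also leaves the read-out at a limit: the limit of > 88000 nM in this assay, at which 1 of the 4 values shown sits.
Going by these compounds alone, the only readable new step is an at least 1.4-fold higher number from compound 2 to compound 4 (0.15 log units; that floor lies within the scatter) and the steps to compound 4 from compound 3 and from compound 1 cannot be read.

On these data alone, what remains open is how far the true values of compound 1, compound 3 and compound 4 lie from their limits. Also open, as far as these compounds go, is whether a longer chain, or a ring carrying an amine or a carboxylic acid, on this nitrogen would give a lower number.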